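Trimming the Linker: Butyl in Place of Butylamino

The source may report more compounds than this note shows. Statements on the series, on what has been measured and on what is new or still open speak of the compounds shown alone.

Of the compounds shown here, three sharing one core have been measured in an assay on HEK-Blue hTLR8 cells for agonist activity at Toll-like receptor 8 (Homo sapiens), read by reporter gene assay and spectrophotometry; a higher number here means that more compound is needed for the effect, a lower number that less compound is needed. Compound 1 `CCCC#Cc1cc2ccccc2nc1N` gives 13000 nM. Compound 2 `CCCCSc1cc2ccccc2nc1N` gives 4160 nM. Compound 3 `CCCCNc1cc2ccccc2nc1N` gives 4280 nM. Among these three numbers compound 3 stands second highest: the step of a 1.0-fold higher number from compound 2 to compound 3 (0.01 log units; within the scatter) lies within the scatter, so compound 2 and compound 3 cannot be told apart, while compound 1 sits clearly apart, as the step of a 3.0-fold lower number from compound 1 to compound 3 (0.48 log units; beyond the scatter) shows.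

Compound 4 `CCCCc1cc2ccccc2nc1N` is the next step: butyl in place of butylamino on an aromatic carbon. Among the measured compounds shown here, two measured steps bear on it loosely. The steps of a 3.1-fold lower number from compound 1 to compound 2 (0.49 log units; beyond the scatter) and a 3.0-fold lower number from compound 1 to compound 3 (0.48 log units; beyond the scatter) show that swapping the pent-1-yn-1-yl chain for a chain held by a sulfur or nitrogen atom brings a modest gain, and the step of a 1.0-fold higher number from compound 2 to compound 3 (0.01 log units; within the scatter) shows that which of those two atoms holds the chain makes no difference. For the measured compounds named here, no measured step removes the holding atom altogether, so the effect of a plain butyl chain is not anchored by precedent. The expectation is a step of a 1.9-fold higher number from compound 3 to compound 4 (0.27 log units; within the scatter) toward a higher number, with wide uncertainty. Compound 4 is therefore estimated at 8000 nM in this assay, with a range from 2500 nM to 25000 nM.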

Compound 4, half-maximal effective concentration: 410 nM
Beside the measured number, compound 4's estimate is 20-fold (1.29 log units) above it, and the stated range ends above it.
By their numbers in this assay, from the lowest: compound 4; then compounds 2 and 3 (each within the scatter of the next); then compound 1.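

Removing the atom that holds the chain turns out to be what matters at this position: butyl gives a 10-fold lower number from compound 3 to compound 4 (1.02 log units; beyond the scatter) in this assay and a 10-fold lower number from compound 2 to compound 4 (1.01 log units; beyond the scatter), while exchanging sulfur for nitrogen gave only a 1.0-fold higher number from compound 2 to compound 3 (0.01 log units; within the scatter). Set against the pent-1-yn-1-yl chain, the same butyl chain gives a 32-fold lower number from compound 1 to compound 4 (1.50 log units; beyond the scatter), so among these four compounds, compound 4 needs the least compound for the effect, and a chain joined directly to the aromatic carbon can outdo both the sulfur-linked and nitrogen-linked chains. Nothing in the data shown accounts for the size of this step.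

On these data alone, whether a shorter propyl chain or a longer pentyl chain on this carbon would give a lower or higher number than compound 4 remains open, as does where a butoxy chain, held by an oxygen atom, would fall. Also open, as far as these compounds go, is whether the advantage of butyl would survive if the amino group ortho to it gave way to a hydroxyl group.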